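Hydroxy for methyl on the aryl of compound 1

The compounds below may be only part of what the source reports. "The series", "measured", "known", "first", "only" and "open" are said of these compounds alone.

Measured so far:
compound 1, `Cc1ccc(-c2cnn3c(NCc4ccccn4)cc(C)nc23)cc1` — < 5000 nM
compound 2, `Cc1cc(NCc2c[nH]cn2)n2nc(C)c(-c3ccccc3)c2n1` — 14600 nM
compound 3, `Cc1cc(NCc2nccs2)n2nc(C)c(-c3ccccc3)c2n1` — 108000 nM

In a physicochemical assay for solubility, read by HPLC, using the shake flask method, measured as kinetic solubility, with a stated time of 2 h, at pH 7.4 (on this read-out higher numbers stand for higher solubility and lower numbers for lower solubility), compound 1 gives only < 5000 nM, which is a limit of the assay and not a number. For the measured compounds named here, it is the one compound here that sits at the limit of < 5000 nM in this assay, at which 1 of the 3 values shown sits. Going by the values given here, compound 2 gives 14600 nM and compound 3 gives 108000 nM; the one measured step, a 7.4-fold higher number from compound 2 to compound 3 (0.87 log units; beyond the scatter), concerns the group on the saturated chain carbon bound to the ring nitrogen, not the aryl ring.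

Compound 4, `Cc1cc(NCc2ccccn2)n2ncc(-c3ccc(O)cc3)c2n1`, differs from compound 1 in another place: hydroxy in place of methyl on an aromatic carbon. No measured step touches this position, so the size and direction of the change rest on no shown pair. Compound 1 stands at the limit, and the two numeric values given by compound 2 and compound 3 set the scale on which compound 4 is judged. The estimate for compound 4 is 15000 nM, between 3000 nM and 60000 nM, and the expected step is an at least 3.0-fold higher number from compound 1 to compound 4 (0.47 log units; beyond the scatter), with a real chance that this assay again reports only a limit.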

Compound 4, solubility: 10900 nM
Beside the measured number, compound 4's estimate is 1.4-fold (0.14 log units) above it; low and high end bracket the measured number.
By their numbers in this assay, from the lowest: compounds 4 and 2 (each within the scatter of the next); then compound 3. At a limit, below all of these: compound 1.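

Hydroxy in place of methyl on an aromatic carbon, para to a large group, gives the first read on this position in this assay: the change from 4-methylphenyl to 4-hydroxyphenyl gives an at least 2.1-fold higher number from compound 1 to compound 4 (0.33 log units; beyond the scatter). For the compounds shown here, no earlier step touched this position, so this result is the first to show that the read-out responds to a change here, and that it moves upward. Compound 1 stands at a limit of the assay and not at a number, so the step gives only a floor and its full size stays unknown: the limit of < 5000 nM in this assay, at which 1 of the 4 values shown sits.

On these data alone, whether the rise is specific to hydroxy stays open, as an amine, a methoxy group or a carboxylic acid in the same place would show. Also open, as far as these compounds go, is whether the same change carries over when the pyridine-bearing side chain gives way to the 1,3-thiazol-2-yl group of compound 3.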